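Oral exposure after removing the pyrazole acyl group

This account rests on a few compounds, and the source may have more. Where it says the series, first, only, none or still open, it means among the compounds named here.

Measured compounds in an ADME assay on the whole organism (Mus musculus, strain ICR) for pharmacokinetics, read by LC-MS, with a stated time of 24 h, at a dose of 10 mg/kg by the oral route; a higher number here means more compound in the circulation at the dose given, a lower number less compound in the circulation:
compound 1 `CCN1CCN(c2cc(Nc3cc(C)nn3C(=O)C(C)(C)C)nc(N[C@H]3CCN(C(=O)c4ccc(Cl)cc4F)C3)n2)CC1` gives 157 ng.h/mL
compound 2 `CCN1CCN(c2cc(Nc3cc(C)nn3C(=O)OC(C)(C)C)nc(N[C@H]3CCN(C(=O)c4ccc(Cl)cc4F)C3)n2)CC1` gives 1130 ng.h/mL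
compound 3 `CCOC(=O)n1nc(C)cc1Nc1cc(N2CCN(CC)CC2)nc(N[C@H]2CCN(C(=O)c3ccc(Cl)cc3F)C2)n1` gives 4050 ng.h/mL

Compound 3 stands highest of the three, with compound 2 nearest at a 3.6-fold higher number from compound 2 to compound 3 (0.55 log units; beyond the scatter) and compound 1 furthest at a 26-fold higher number from compound 1 to compound 3 (1.41 log units; beyond the scatter). The three compounds differ only in the group on the carbonyl carbon attached to the pyrazole nitrogen, and the step of a 7.2-fold higher number from compound 1 to compound 2 (0.86 log units; beyond the scatter) completes the set.

Compound 4 `CCN1CCN(c2cc(Nc3cc(C)[nH]n3)nc(N[C@H]3CCN(C(=O)c4ccc(Cl)cc4F)C3)n2)CC1` takes a different direction: 5-methyl-1H-pyrazol-3-yl in place of 1-(ethoxycarbonyl)-3-methyl-1H-pyrazol-5-yl on a nitrogen on an aromatic ring. The whole ethoxycarbonyl group is gone, so the pyrazole now carries a hydrogen on its ring nitrogen. Among the compounds with values here, none of the measured steps covers this change; each of them swaps one carbonyl substituent for another while keeping the carbonyl in place. What the measured steps do show is that this assay is sensitive to the group on that nitrogen, with the numbers spanning a wide range across compounds 1, 2 and 3.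

Within the data shown here, with no step that bears directly on the change, the expected step from compound 3 to compound 4 in this assay is given as a 2.0-fold lower number from compound 3 to compound 4 (0.31 log units; beyond the scatter) with a wide range. Compound 4 is therefore estimated at 2000 ng.h/mL, within 400 ng.h/mL to 10000 ng.h/mL.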

Compound 4, area under the concentration-time curve: 533 ng.h/mL
Compound 4: the middle estimate sits 3.8-fold (0.57 log units) above what was measured, and the stated range covers the measured number.
By their numbers in this assay, from the lowest: compound 1; then compound 4; then compound 2; then compound 3.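

Within the data shown here, with the carbonyl group gone altogether, the free pyrazole can be set against the acylated compounds in this assay for the first time, and the direction of the change depends on which acyl group is removed. Losing the ethoxycarbonyl group gives a 7.6-fold lower number from compound 3 to compound 4 (0.88 log units; beyond the scatter) and so costs exposure, whereas replacing the tert-butyl carbonyl group gives a 3.4-fold higher number from compound 1 to compound 4 (0.53 log units; beyond the scatter) and so gains it. A carbonyl group on this pyrazole nitrogen therefore does not by itself raise or lower the number, since the ethyl carbamate stands above the compound with the ring hydrogen and the tert-butyl ketone-type acyl compound stands below it, with compound 4 at 533 ng.h/mL inside the span of the acylated compounds. No measurement shown here explains why the three acyl groups fall on different sides of the free pyrazole.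

Going by these compounds, it remains open where a methoxycarbonyl or a longer chain such as n-butoxycarbonyl would fall relative to the ethoxycarbonyl group. Equally open, on these data alone, is whether a simple acetyl group, or an alkyl group such as methyl with no carbonyl at all, would sit above or below compound 4 on this nitrogen.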